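A few compounds are considered here, and "the series" means these few. Any claim that something is new, unique, unknown or untested is made for them only; others in the source may bear on it.

Compound 3, `Cc1ccc(Nc2nccc(-c3c(C)nc4ccccn34)n2)cc1`, stands together with compound 1 at the top of the three numbers in hand. In a functional assay on U-251 cells (Homo sapiens) for cytotoxicity, read by sulforhodamine B assay, with a stated time of 48 h, tested at 50 uM (on this read-out lower numbers stand for less inhibition and higher numbers for more inhibition at the one concentration tested (going by the name of the read-out)), compound 3 gives 100%, and compound 1, `Cc1ccc(Nc2nccc(-c3ccnc4ccccc34)n2)cc1`, gives 100%, the two being level within the scatter. Compound 2, `FC(F)(F)c1ccc(Nc2nccc(-c3cnc4ccccc4c3)n2)cc1`, gives 49.8% in this assay, a number well below compound 3 and beyond the scatter. Compound 4, `Cc1nc2ccccn2c1-c1ccnc(Nc2ccc(C=O)s2)n1`, differs from compound 3 by 5-formylthiophen-2-yl in place of 4-methylphenyl on a nitrogen on an aromatic ring. Among the measured compounds shown here, no measured pair shows this exchange, so its effect is not known; with compound 3 already at the ceiling of the read-out, no rise is possible, and a drop of moderate size is the expected direction, so the step from compound 3 to compound 4 is estimated at a number 25 percentage points lower from compound 3 to compound 4 (beyond the scatter). Compound 4 is therefore expected to give 75%, with a range from 35% to 100%.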

Compound 4, a percentage reported as inhibition, at one concentration (the size of the read-out at that concentration, not a potency): 57.8%
Estimate against measurement, compound 4: 17.2 percentage points above; the measured number falls inside the stated range.
By their numbers in this assay, from the lowest: compounds 2 and 4 (each within the scatter of the next); then compounds 1 and 3 (each within the scatter of the next).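

In this assay, the exchange of 4-methylphenyl for 5-formylthiophen-2-yl on a nitrogen on an aromatic ring gives a number 42.2 percentage points lower from compound 3 to compound 4 (beyond the scatter). Among the compounds shown here, this is the first single-place change in hand, and it shows that the read-out at this position responds to the group carried there, even though both groups count 7 heavy atoms. Nothing available explains the size of this step. The compounds shown leave open whether the change follows the thiophene ring or the formyl group. A plain thiophen-2-yl, or a 5-carboxythiophen-2-yl, would bear on that question.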